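Swapping Trifluoromethyl for Phenyl in a Growth Inhibition Series

A few compounds are considered here, and "the series" means these few. Any claim that something is new, unique, unknown or untested is made for them only; others in the source may bear on it.

Compound 1 `C/C(=N\O)c1ccc(NC(=O)Cn2nc(-c3ccc(Cl)cc3)nc2N)cc1`: 31.5%
Compound 2 `C/C(=N/O)c1ccc(NC(=O)Cn2nc(C(F)(F)F)nc2N)cc1`: 31%
Compound 3 `COc1cc(-c2nc3sc(-c4ccccc4)cn3n2)cc(OC)c1OC`: 30%

All three compounds were tested in a functional assay on NCI-H522 cells (Homo sapiens) for inhibition, read by sulforhodamine B assay, with a stated time of 48 h, tested at 10 uM; on this read-out higher numbers stand for more inhibition of growth at the one concentration tested and lower numbers for less inhibition of growth. A single concentration gives one number per compound, so small gaps between compounds carry little meaning. Compound 2 gives 31%, and this number lies within the usual scatter of the values for both other compounds, so the three cannot be ranked.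

The next compound is compound 4 `C/C(=N/O)c1ccc(NC(=O)Cn2nc(-c3ccccc3)nc2N)cc1`, which differs from compound 2 in one group: phenyl in place of trifluoromethyl on an aromatic carbon. This puts phenyl in place of trifluoromethyl on an aromatic carbon, between two ring nitrogen atoms.

For the measured compounds named here, no two measured compounds differ in just one place, so the data offer no direct guide to the effect of this swap. They show only a narrow band, with compound 1 at 31.5% and compound 3 at 30%. On that basis, no change beyond the scatter is expected in this assay, and neither direction is favoured. The expected step of a number 1 percentage points higher from compound 2 to compound 4 (within the scatter) is small and stays within the scatter. For compound 4 the estimated value is 32%, with an expected range from 15% to 50%.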

Compound 4, percent growth inhibition at one concentration: 30%
Beside the measured number, compound 4's estimate is 2 percentage points above it; low and high end bracket the measured number.
By their numbers in this assay, from the lowest: compounds 3, 4, 2 and 1 (each within the scatter of the next).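

In this assay, for the compounds shown here, the step of a number 1 percentage points lower from compound 2 to compound 4 (within the scatter) gives the first direct reading at this position, on an aromatic carbon between two ring nitrogen atoms, and it lies within the scatter. The swap replaces trifluoromethyl, with 4 heavy atoms and no ring, by phenyl, with 6 heavy atoms and a six-membered aromatic ring, so this single comparison shows that a clearly different group at this position can leave the read-out without a change beyond the scatter. Nothing measured here explains why these two groups give such similar readings.

Going by these compounds alone, compounds 2 and 4 cover only two groups at this position, so it remains open whether an amine, a carboxylic acid or a longer chain on this aromatic carbon would move the number beyond the scatter. Each compound also has a reading at only one concentration, which leaves open whether compound 2 and compound 4 would still read alike at other concentrations.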